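Moving the chlorine on the urea aryl ring of compound 2

The source may report more compounds than this note shows. Statements on the series, on what has been measured and on what is new or still open speak of the compounds shown alone.

Of the compounds shown here, two have been tested in a functional assay on MKN-45 cells (Homo sapiens) for cytotoxicity, read by MTT assay, with a stated time of 72 h; on this read-out lower numbers stand for stronger inhibition and higher numbers for weaker inhibition. Compound 1, `CN(C)CCCNc1nc(-c2ccc(NC(=O)Nc3ccccc3Cl)cc2)nc2c(Cl)c(Cl)sc12`, gives 1330 nM in this assay. Compound 2, `CCN(CC)CCNc1nc(-c2ccc(NC(=O)Nc3ccc(Cl)cc3)cc2)nc2c(Cl)c(Cl)sc12`, gives 890 nM in this assay. The two numbers lie within the scatter of each other, so compound 2 cannot be set apart from compound 1 on the data shown; the two also differ in more than one place, in the chain on the amino group and in the chloro-substituted phenyl ring, so neither difference can be read on its own.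

Compound 3, `CCN(CC)CCNc1nc(-c2ccc(NC(=O)Nc3ccccc3Cl)cc2)nc2c(Cl)c(Cl)sc12`, has not yet been measured. It differs from compound 2 by 2-chlorophenyl in place of 4-chlorophenyl on an amide-type nitrogen. Compound 1 carries the same 2-chlorophenyl ring, and its number sits close to that of compound 2, which gives no reason to expect a large movement in either direction. Compound 3 is therefore expected to give about 1100 nM in this assay, likely between 500 nM and 2500 nM, a step of a 1.2-fold higher number from compound 2 to compound 3 (0.09 log units; within the scatter) that is expected to stay within the scatter.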

Compound 3, half-maximal inhibitory concentration: 1130 nM
Beside the measured number, compound 3's estimate is 1.0-fold (0.01 log units) below it, within the range that was stated.
By their numbers in this assay, from the lowest: compounds 2, 3 and 1 (each within the scatter of the next).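

In this assay the exchange of 4-chlorophenyl for 2-chlorophenyl on the amide-type nitrogen gives a 1.3-fold higher number from compound 2 to compound 3 (0.10 log units; within the scatter) with the rest of the structure held constant, so where the chlorine sits on this ring does not separate these two compounds in this assay. The earlier pair mixed two differences, but the chain difference can now be read by itself: diethylamino in place of (dimethylamino)methyl, on a saturated chain carbon two bonds along the chain from a nitrogen on an aromatic ring, gives a 1.2-fold lower number from compound 1 to compound 3 (0.07 log units; within the scatter) and also stays within the scatter. No supporting measurement is available to explain either step. 

On these data alone, these compounds cover only two placements of one chlorine and two amine chains, so it remains open whether a number beyond the scatter would follow from an unsubstituted phenyl ring, or from a fluorine or a methoxy group in place of the chlorine. As far as these compounds go, it is equally open how a pyrrolidine or morpholine at the end of the chain, or a longer chain, would read in this assay.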